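A few compounds are considered here, and "the series" means these few. Any claim that something is new, unique, unknown or untested is made for them only; others in the source may bear on it.

In a functional assay on U-251 cells (Homo sapiens) for inhibition, read by sulforhodamine B assay, with a stated time of 48 h (on this read-out higher numbers stand for weaker inhibition of growth and lower numbers for stronger inhibition of growth), compound 3 `O=C(Cc1csc2nc(-c3ccc(Br)cc3)cn12)N/N=C/c1ccc(O)cc1` gives > 100000 nM, which is a limit of the assay and not a number. Compound 1 `O=C(Cc1csc2nc(-c3ccc(Br)cc3)cn12)N/N=C/c1ccccc1` gives 32400 nM, and compound 2 `O=C(Cc1csc2nc(-c3ccc(Br)cc3)cn12)N/N=C/c1ccccc1O` gives 15100 nM. Compound 4 `COc1cccc(OC)c1/C=N/NC(=O)Cc1csc2nc(-c3ccc(Br)cc3)cn12` differs from compound 3 by 2,6-dimethoxyphenyl in place of 4-hydroxyphenyl on a carbon with a double bond to nitrogen. Within the data shown here, three measured steps bear on this change: a 2.1-fold lower number from compound 1 to compound 2 (0.33 log units; beyond the scatter), an at least 3.0-fold higher number from compound 1 to compound 3 (0.48 log units; beyond the scatter) and an at least 6.6-fold higher number from compound 2 to compound 3 (0.82 log units; beyond the scatter). Each is beyond the scatter, and the direction depends on where the hydroxy sits. Compound 4 carries no hydroxy, so compound 1 at 32400 nM is the closest guide, and a modest move towards stronger inhibition of growth is expected. The expected change is an at least 3.3-fold lower number from compound 3 to compound 4 (0.52 log units; beyond the scatter). For compound 4 the estimated value is 30000 nM, with an expected range of 10000 nM to 100000 nM.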

Compound 4, concentration for total growth inhibition: 31600 nM
The estimate for compound 4 lay 1.1-fold (0.02 log units) below the measured number; low and high end bracket the measured number.
By their numbers in this assay, from the lowest: compound 2; then compounds 4 and 1 (each within the scatter of the next). At a limit, above all of these: compound 3.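

In this assay, 2,6-dimethoxyphenyl and phenyl on this carbon read alike (a 1.0-fold lower number from compound 1 to compound 4 (0.01 log units; within the scatter)), so the two methoxy groups leave the number unchanged within the scatter. The 2-hydroxyphenyl of compound 2 still gives stronger inhibition of growth (a 2.1-fold higher number from compound 2 to compound 4 (0.32 log units; beyond the scatter)), while 2,6-dimethoxyphenyl clearly outperforms 4-hydroxyphenyl (an at least 3.1-fold lower number from compound 3 to compound 4 (0.50 log units; beyond the scatter)). That last step is open-ended, since the value of compound 3 is a limit and not a number: the limit of > 100000 nM in this assay, at which 1 of the 4 values shown sits.

From the compounds shown here alone, it remains open whether an amine or a carboxylic acid on this phenyl ring would give a lower number than compound 2.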